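Trifluoromethyl in place of fluoro on compound 3

A few compounds are considered here, and "the series" means these few. Any claim that something is new, unique, unknown or untested is made for them only; others in the source may bear on it.

Measured in an ADME assay on Vero cells (Chlorocebus sabaeus) for cytotoxicity, read by resazurin assay, with a stated time of 72 h; a higher number here means a weaker inhibitor, a lower number a stronger inhibitor:
compound 1 `O=C(CCN1CCN(c2ccc(C(F)(F)F)cc2)CC1)c1ccccc1`: 15700 nM
compound 2 `COc1ccc(C(=O)CCN2CCN(c3ccc(C(F)(F)F)cc3)CC2)cc1OC`: 243000 nM
compound 3 `O=C(CCN1CCN(c2ccc(F)cc2)CC1)c1ccc(F)c(Br)c1`: 352000 nM

In this assay compound 3 gives 352000 nM, within the scatter of compound 2, and both numbers lie well above that of compound 1.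

The unmeasured compound 4 `O=C(CCN1CCN(c2ccc(C(F)(F)F)cc2)CC1)c1ccc(F)c(Br)c1` keeps the rest of compound 3 but has trifluoromethyl in place of fluoro on an aromatic carbon, para to a large group: trifluoromethyl in place of fluoro on an aromatic carbon. Among the compounds with values here, no measured step makes this change. The only one available, a 15-fold higher number from compound 1 to compound 2 (1.19 log units; beyond the scatter), is a large step at another place, between two compounds that both carry trifluoromethyl. It bears on compound 4 only by showing how widely such compounds can differ, from compound 1 at 15700 nM to compound 2 at 243000 nM. Compound 4 is expected to fall inside that span, so a moderate move to a lower number is expected, though compound 2 shows that none may appear. The estimated step is a 5.9-fold lower number from compound 3 to compound 4 (0.77 log units; beyond the scatter). For compound 4 the estimated value is 60000 nM, with an expected range from 15000 nM to 250000 nM.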

Compound 4, half-maximal inhibitory concentration: 66800 nM
Compound 4: the middle estimate sits 1.1-fold (0.05 log units) below what was measured; the range from low to high includes it.
By their numbers in this assay, from the lowest: compound 1; then compound 4; then compounds 2 and 3 (each within the scatter of the next).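

The change from fluoro to trifluoromethyl on an aromatic carbon, para to a large group, gives a 5.3-fold lower number from compound 3 to compound 4 (0.72 log units; beyond the scatter) in this assay, the first step seen at this position. With trifluoromethyl held in place, the group on the carbonyl carbon still shifts the number: 3-bromo-4-fluorophenyl gives a 4.3-fold higher number from compound 1 to compound 4 (0.63 log units; beyond the scatter) when it replaces phenyl, and a 3.6-fold lower number from compound 2 to compound 4 (0.56 log units; beyond the scatter) when it replaces 3,4-dimethoxyphenyl. The data offer nothing that accounts for these steps.

Going by these compounds, the fluoro to trifluoromethyl step rests on a single pair, so whether it carries over to other groups on the carbonyl carbon remains open. On these data alone, how a nitrile, an amine or a carboxylic acid on this aromatic carbon would read in this assay also remains open.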